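Smaller Halogenated Ring on the Amide Carbonyl

The source may hold more compounds than are shown below. What is called first, only, known or untested is meant among the compounds shown, and "the series" means these compounds.

Of the compounds shown here, two built on one shared core have so far been tested in a functional assay on A549 cells (Homo sapiens) for antiproliferative activity, read by CCK-8 assay, with a stated time of 72 h; on this read-out higher numbers stand for weaker inhibition and lower numbers for stronger inhibition. Compound 1 `COc1ccc(C(=O)Nc2cccc(-c3oc4cc(-c5ccc(F)cc5)ccc4c(=O)c3O)c2)cc1` carries a methoxy group on the aromatic ring attached to its amide carbonyl, and in this assay compound 1 gives 8700 nM. Compound 2 `O=C(Nc1cccc(-c2oc3cc(-c4ccc(F)cc4)ccc3c(=O)c2O)c1)c1ccc(C(F)(F)F)cc1` differs from it only by a trifluoromethyl in place of that methoxy; in this assay compound 2 gives 19400 nM. The exchange produced a 2.2-fold higher number from compound 1 to compound 2 (0.35 log units; beyond the scatter), so compound 2 stands as the higher, that is weaker, of the two numbers seen so far.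

Compound 3 `O=C(Nc1cccc(-c2oc3cc(-c4ccc(F)cc4)ccc3c(=O)c2O)c1)c1cccc(F)c1` is the next candidate: 3-fluorophenyl in place of 4-(trifluoromethyl)phenyl on a carbonyl carbon. For the measured compounds named here, the only measured step, from compound 1 to compound 2, also altered this ring and moved the number modestly, but no measured pair shows what a 3-fluorophenyl does here. A number between the two known values is therefore expected, meaning a step of a 1.8-fold lower number from compound 2 to compound 3 (0.25 log units; within the scatter). Compound 3 is estimated at 11000 nM, within a range from 4000 nM to 30000 nM.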

Compound 3, half-maximal inhibitory concentration: 15400 nM
Estimate against measurement, compound 3: 1.4-fold (0.15 log units) below; the measured number falls inside the stated range.
By their numbers in this assay, from the lowest: compounds 1, 3 and 2 (each within the scatter of the next, the first and the last beyond it).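

Exchanging 4-(trifluoromethyl)phenyl, with 10 heavy atoms, for 3-fluorophenyl, with 7, on the carbonyl carbon gives a 1.3-fold lower number from compound 2 to compound 3 (0.10 log units; within the scatter) in this assay, and exchanging the 4-methoxyphenyl of compound 1 for the same ring gives a 1.8-fold higher number from compound 1 to compound 3 (0.25 log units; within the scatter) in that assay. Compound 3 therefore cannot be told apart from either of the other two compounds, even though those two are separated by a 2.2-fold higher number from compound 1 to compound 2 (0.35 log units; beyond the scatter) and so differ beyond the scatter; at this position, the smaller fluorinated ring neither clearly improves on nor clearly falls short of the larger groups, and all three numbers stay close together. Nothing measured alongside these numbers bears on the reason for this result.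

The step to compound 3 changes both the group on the ring and where it sits, so these compounds cannot show how a 4-fluorophenyl would compare with the 3-fluorophenyl. Every ring shown carries only a methoxy, a trifluoromethyl or a fluorine, which leaves open what an amine or a carboxylic acid on that ring would do.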